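Swapping methyl for isopropyl on compound 2

A few compounds are considered here, and "the series" means these few. Any claim that something is new, unique, unknown or untested is made for them only; others in the source may bear on it.

Of the compounds shown here, three sharing one core have been measured in an ADME assay on microsomes (Mus musculus) for metabolic stability; on this read-out higher numbers stand for fast clearance and lower numbers for slow clearance. Compound 1 `CNC(=O)[C@@H]1CCCN1S(=O)(=O)c1ccc(Cl)c(COc2cccc3c(C(F)(F)F)cc(C)nc23)c1Cl` gives 1380 mL/min/kg, compound 3 `CNC(=O)[C@@H]1CCCN1S(=O)(=O)c1ccc(Cl)c(COc2cccc3c(-c4nccn4C)cc(C)nc23)c1Cl` gives 917 mL/min/kg, and compound 2 `CNC(=O)[C@@H]1CCCN1S(=O)(=O)c1ccc(Cl)c(COc2cccc3c(-c4cncn4C)cc(C)nc23)c1Cl` gives 117 mL/min/kg, the lowest number of the three and clearly apart from both others.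

The next compound, compound 4 `CNC(=O)[C@@H]1CCCN1S(=O)(=O)c1ccc(Cl)c(COc2cccc3c(-c4cncn4C)cc(C(C)C)nc23)c1Cl`, differs from compound 2 in one group: isopropyl in place of methyl on an aromatic carbon, next to the ring nitrogen (isopropyl in place of methyl on an aromatic carbon).

The measured steps all concern a different group. Putting 1-methyl-1H-imidazol-5-yl in place of trifluoromethyl gave a 12-fold lower number from compound 1 to compound 2 (1.07 log units; beyond the scatter), while 1-methyl-1H-imidazol-2-yl in the same place gave a 1.5-fold lower number from compound 1 to compound 3 (0.18 log units; within the scatter). Exchanging the two imidazolyl groups gave a 7.8-fold higher number from compound 2 to compound 3 (0.89 log units; beyond the scatter). None of these steps touches the methyl, so the data hold no direct measure for this change. Going by the values given here, they show only that one swap can move the number a long way in this small set, and the other two compounds both lie above compound 2. A small rise is therefore the cautious expectation, with a wide margin on either side. The expected step is a 1.6-fold higher number from compound 2 to compound 4 (0.21 log units; within the scatter). In this assay, compound 4 is expected at 190 mL/min/kg, with an estimated range from 80 mL/min/kg to 450 mL/min/kg.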

Compound 4, clearance: 100 mL/min/kg
Beside the measured number, compound 4's estimate is 1.9-fold (0.28 log units) above it; the range from low to high includes it.
By their numbers in this assay, from the lowest: compounds 4 and 2 (each within the scatter of the next); then compounds 3 and 1 (each within the scatter of the next).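

In this assay, going from methyl to isopropyl on the aromatic carbon next to the ring nitrogen gives a 1.2-fold lower number from compound 2 to compound 4 (0.07 log units; within the scatter), so this swap, from 1 heavy atom to 3, leaves the two compounds indistinguishable on this read-out. Going by these compounds alone, this is the first measured step at this position, and it contrasts with the exchange of the two imidazolyl groups elsewhere on the shared core, which gave a 7.8-fold higher number from compound 2 to compound 3 (0.89 log units; beyond the scatter); in this pair, the larger group at this position costs nothing measurable in clearance. No measurement here explains this tolerance of the larger group.

As far as these compounds go, this rests on a single pair, so it remains open whether a longer chain, an amine or a carboxylic acid on the same carbon would also leave the number in place. Also open, from the compounds shown here alone, is whether isopropyl would act the same way with 1-methyl-1H-imidazol-2-yl, as in compound 3 at 917 mL/min/kg, or with trifluoromethyl, as in compound 1 at 1380 mL/min/kg, in place of the 1-methyl-1H-imidazol-5-yl group.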